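A smaller fluoro group on the shared core

The source may report more compounds than this note shows. Statements on the series, on what has been measured and on what is new or still open speak of the compounds shown alone.

In a physicochemical assay for solubility, read by HPLC, in phosphate buffer, with a stated time of 16 h, at pH 6.8 (on this read-out lower numbers stand for lower solubility and higher numbers for higher solubility), the numbers so far are these
- compound 1 `Cc1ccc([C@H](C)NC(=O)Cn2nnc3ccccc3c2=O)cc1` gives 12000 nM
- compound 2 `Cc1ccc([C@H](C)NC(=O)Cn2nnc3ccc(C(F)(F)F)cc3c2=O)cc1` gives 6600 nM
- compound 3 `Cc1ccc([C@H](C)NC(=O)Cn2nnc3ccc(F)cc3c2=O)cc1` is not yet measured

Going by the values given here, compound 2 stands within the scatter of compound 1, the only other compound measured. Compound 3 differs from compound 2 in one place (fluoro in place of trifluoromethyl on an aromatic carbon) with fluoro in place of trifluoromethyl on an aromatic carbon. Among the compounds with values here, the one measured step that bears on this is trifluoromethyl in place of hydrogen on an aromatic carbon (a 1.8-fold lower number from compound 1 to compound 2 (0.26 log units; within the scatter)), so no step beyond the scatter is expected in this assay here. The estimated step is small (a 1.4-fold higher number from compound 2 to compound 3 (0.13 log units; within the scatter)). Compound 3 is estimated at 9000 nM with an expected range from 4500 nM to 18000 nM when measured.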

Compound 3, solubility: 3400 nM
Estimate against measurement, compound 3: 2.6-fold (0.42 log units) above; the measured number lies below the stated range.
By their numbers in this assay, from the lowest: compounds 3, 2 and 1 (each within the scatter of the next, the first and the last beyond it).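

In this assay, going by these compounds alone, fluoro in place of hydrogen on this aromatic carbon gives a 3.5-fold lower number from compound 1 to compound 3 (0.55 log units; beyond the scatter) and is the first step at this position to lie beyond the scatter. Fluoro in place of trifluoromethyl gives a 1.9-fold lower number from compound 2 to compound 3 (0.29 log units; within the scatter), so these two groups cannot be told apart at this position in this read-out. Nothing measured here offers an explanation for these numbers.

The compounds shown leave open whether an amine, a carboxylic acid or a methoxy group on this carbon would give a number above that of compound 1. They also leave open whether fluoro would give a similar step elsewhere on the shared core.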